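The compounds below may be only part of what the source reports. "The series", "measured", "known", "first", "only" and "open" are said of these compounds alone.

Values in an ADME assay on MRC5 cells (Homo sapiens) for cytotoxicity, read by fluorescence and resazurin assay, with a stated time of 3 days (on this read-out higher numbers stand for weaker inhibition and lower numbers for stronger inhibition), are:
- Compound 1 `Cc1cn(C2CCN(Cc3cccc(Oc4ccc(Cl)cc4)c3)CC2)c(=O)[nH]c1=O` gives 25100 nM
- Compound 2 `Cc1cn(C2CCN(Cc3cccc(Oc4cc(F)cc(F)c4)c3)CC2)c(=O)[nH]c1=O` gives > 64000 nM as a limit of the assay
- Compound 3 `Cc1cn(C2CCN(Cc3cccc(Oc4ccc(Cl)c(Cl)c4)c3)CC2)c(=O)[nH]c1=O` gives 6100 nM

Compound 3 has the lower of the two true numbers, and compound 1 is nearest at 25100 nM in this assay. Compound 4 `Cc1cn(C2CCN(Cc3cccc(Oc4ccc(Cl)c(C(F)(F)F)c4)c3)CC2)c(=O)[nH]c1=O` carries trifluoromethyl in place of chloro on an aromatic carbon with trifluoromethyl in place of chloro on an aromatic carbon, ortho to a chloro group. The closest measured step is a 4.1-fold lower number from compound 1 to compound 3 (0.61 log units; beyond the scatter) and it gained the chloro that leaves here. The larger at least 10-fold lower number from compound 2 to compound 3 (1.02 log units; beyond the scatter) starts from a limit. Neither step exchanges chloro for trifluoromethyl, so no step beyond the scatter is expected. The expected result is a 1.0-fold lower number from compound 3 to compound 4 (0.01 log units; within the scatter) in this assay for this exchange. Compound 4 is estimated at 6000 nM with an expected range from 2500 nM to 16000 nM in this assay.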

Compound 4, half-maximal inhibitory concentration: 5280 nM
The estimate for compound 4 lay 1.1-fold (0.06 log units) above the measured number, within the range that was stated.
By their numbers in this assay, from the lowest: compounds 4 and 3 (each within the scatter of the next); then compound 1. At a limit, above all of these: compound 2.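

In this assay, trifluoromethyl and chloro are interchangeable at this position, ortho to a chloro group, with a 1.2-fold lower number from compound 3 to compound 4 (0.06 log units; within the scatter); a 4.8-fold lower number from compound 1 to compound 4 (0.68 log units; beyond the scatter) shows that the gain over compound 1 does not depend on chloro alone. Compound 2 stands at a limit of the assay: the limit of > 64000 nM in this assay, at which 1 of the 4 values shown sits. The step to compound 4 therefore reads only as a bound: an at least 12-fold lower number from compound 2 to compound 4 (1.08 log units; beyond the scatter).

On these data alone, whether this position tolerates only such non-donor, non-acceptor groups remains open. An amine or a carboxylic acid here could test this.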